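Bisindolylquinone series: prenyl on the indole carbon

A few compounds are considered here, and "the series" means these few. Any claim that something is new, unique, unknown or untested is made for them only; others in the source may bear on it.

Measured so far:
compound 1, `C=C1C(=O)C[C@H]2[C@@H]3CC[C@H](C(=O)O)[C@]12CC3(C)C`, 24100 nM
compound 2, `COC1=C(c2c[nH]c3ccccc23)C(=O)C(OC)=C(c2c[nH]c3ccccc23)C1=O`, 17700 nM

Both numbers come from a functional assay on MCF7 cells (Homo sapiens) for cytotoxicity, read by MTT assay, with a stated time of 48 h; a higher number here means a weaker inhibitor, a lower number a stronger inhibitor. Compound 2 carries the lower of the two, but the gap to compound 1 lies within the scatter of repeat runs, so the two sit on the same footing and neither can be called the more active. Among the compounds with values here, with only these two points there is no measured step to lean on.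

Compound 3, `C=CC(C)(C)c1[nH]c2ccccc2c1C1=C(OC)C(=O)C(c2c[nH]c3ccccc23)=C(OC)C1=O`, is the untested member. It differs from compound 2 in one place:

1,1-dimethylprop-2-en-1-yl in place of hydrogen on an aromatic carbon

The change is the entry of the 1,1-dimethylprop-2-en-1-yl group on an aromatic carbon next to the ring nitrogen. Within the data shown here, no pair in the data shows what such an addition does in this assay, so any expectation rests on compound 2 alone. The working guess is a modest move toward a lower number, of a size expected at a 1.8-fold lower number from compound 2 to compound 3 (0.25 log units; within the scatter), on the reading that an added group of this kind rarely shifts a value far in a single step. On that basis compound 3 is expected to give about 10000 nM, with a likely range from 3000 nM to 30000 nM.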

Compound 3, half-maximal inhibitory concentration: 4100 nM
For compound 3 the middle estimate is 2.4-fold (0.39 log units) above the measured one, and the stated range covers the measured number.
By their numbers in this assay, from the lowest: compound 3; then compounds 2 and 1 (each within the scatter of the next).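

In this assay, within the data shown here, the aromatic carbon next to the ring nitrogen, on the five-membered aromatic ring, accepts a substituent without loss of activity: 1,1-dimethylprop-2-en-1-yl in place of hydrogen gives the first measured step (a 4.3-fold lower number from compound 2 to compound 3 (0.64 log units; beyond the scatter)). That step lies beyond the scatter, so this position can change the number in this cell assay, and the change is a gain of activity rather than a neutral addition. The entering group has no ring, no hydrogen-bond donors and no hydrogen-bond acceptors, yet nothing at hand explains the gain, and the result rests on this single pair with no supporting measurement behind it.

Whether the gain needs this particular branched group stays open, since neither a plain methyl group, a longer unbranched chain nor an amine at the same carbon appears among the compounds shown. Also open, going by these compounds, is whether 1,1-dimethylprop-2-en-1-yl on the second, still unsubstituted five-membered ring of compound 3 would lower the number further or leave it unchanged.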